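The compounds below may be only part of what the source reports. "The series", "measured", "known", "first", "only" and "open" are said of these compounds alone.

Within the data shown here, in a physicochemical assay for lipophilicity, using the shake flask method (a higher number here means a more lipophilic compound, a lower number a more polar compound), compound 1 `Nc1ncnc(Oc2ccc(NC(=O)C3(C(=O)Nc4ccc(F)cc4)CC3)cc2F)c1/C=N/O` gives 2.62 and compound 2 `Nc1ncnc(Oc2ccc(NC(=O)C3(C(=O)Nc4ccc(F)cc4)CC3)cc2F)c1/C=N/OCCCO` gives 2.67 while compound 3 `CCOC(=O)CO/N=C/c1c(N)ncnc1Oc1ccc(NC(=O)C2(C(=O)Nc3ccc(F)cc3)CC2)cc1F` stands highest of the three at 3.15 on the numbers so far. Compound 4 `CCCCO/N=C/c1c(N)ncnc1Oc1ccc(NC(=O)C2(C(=O)Nc3ccc(F)cc3)CC2)cc1F` is still unmeasured. It differs from compound 3 by propyl in place of ethoxycarbonyl on a saturated chain carbon bound to an oxygen on an unsaturated carbon. Among the measured compounds shown here, no measured step makes this exact change, and no measured compound carries butyl. The nearest step is a number 0.48 log units higher from compound 2 to compound 3 (beyond the scatter) with ethoxycarbonyl in place of 2-hydroxyethyl, and a number 0.53 log units higher from compound 1 to compound 3 (beyond the scatter) is of similar size, whereas a number 0.05 log units higher from compound 1 to compound 2 (within the scatter) shows no real change. A further modest rise is expected, estimated as a number 0.45 log units higher from compound 3 to compound 4 (beyond the scatter) in this assay for now. The estimate for compound 4 is 3.6 with 3.2 to 4 as the expected range.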

Compound 4, partition coefficient: 4.2
Beside the measured number, compound 4's estimate is 0.60 log units below it; the measured number lies above the stated range.
By their numbers in this assay, from the lowest: compounds 1 and 2 (each within the scatter of the next); then compound 3; then compound 4.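

In this assay, among these compounds, the group on this oxygen can move the number far more than the earlier compounds showed: butyl in place of hydrogen gives a number 1.58 log units higher from compound 1 to compound 4 (beyond the scatter) as the largest step so far. Single swaps within the chain also matter: propyl in place of ethoxycarbonyl gives a number 1.05 log units higher from compound 3 to compound 4 (beyond the scatter) and methyl in place of hydroxy gives a number 1.53 log units higher from compound 2 to compound 4 (beyond the scatter) in the same direction. The all-carbon butyl chain thus stands well apart from both chains that carry extra oxygen atoms. As far as these compounds go, whether an amine or a longer chain here would go further stays open. No measurement shown explains the size of these steps.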